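The source may hold more compounds than are shown below. What is called first, only, known or untested is meant among the compounds shown, and "the series" means these compounds.

Working notes on the series. In an assay on isolated protein for inhibition of Rho-associated protein kinase 2 (Homo sapiens), read by scintillation counting, radiometric assay and 33P incorporation, with a stated time of 40 min, in the presence of a further agent that is not named here (on this read-out lower numbers stand for stronger inhibition and higher numbers for weaker inhibition), compound 1 `CCCC(=O)Nc1cccc(NC(=O)COc2ccc3c(=O)ccoc3c2)c1` gives 176 nM. Compound 2 `CCOc1ccc(C(=O)Nc2cccc(NC(=O)COc3ccc4c(=O)ccoc4c3)c2)cc1` gives 9 nM in this assay, and compound 3 `O=C(COc1ccc2c(=O)ccoc2c1)Nc1cccc(NC(=O)c2cnc(C(F)(F)F)s2)c1` gives 10 nM there. Compound 3 thus sits second highest of the three numbers, within the scatter of compound 2 and far from compound 1: the steps of a 20-fold lower number from compound 1 to compound 2 (1.29 log units; beyond the scatter) and an 18-fold lower number from compound 1 to compound 3 (1.25 log units; beyond the scatter) are both large, while a 1.1-fold higher number from compound 2 to compound 3 (0.05 log units; within the scatter) lies within the scatter, so the two aromatic amides are not separated.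

Compound 4 `Nc1ccc(C(=O)Nc2cccc(NC(=O)COc3ccc4c(=O)ccoc4c3)c2)cc1` is the next member: 4-aminophenyl in place of 2-(trifluoromethyl)-1,3-thiazol-5-yl on a carbonyl carbon. The step that bears on it most directly is the one from an aromatic ring to another aromatic ring at the same carbonyl carbon, a 1.1-fold higher number from compound 2 to compound 3 (0.05 log units; within the scatter), which was flat; the large gains from compound 1 came from leaving propyl, which compound 4 does not revisit. A step of no size beyond the scatter is therefore expected in this assay, with the new aromatic ring kept. For compound 4 the estimate is 15 nM, with a range from 5 nM to 50 nM, which means an expected step of a 1.5-fold higher number from compound 3 to compound 4 (0.18 log units; within the scatter).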

Compound 4, half-maximal inhibitory concentration: 83 nM
The estimate for compound 4 lay 5.5-fold (0.74 log units) below the measured number; the whole stated range lies below it.
By their numbers in this assay, from the lowest: compounds 2 and 3 (each within the scatter of the next); then compound 4; then compound 1.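

At the carbonyl carbon in this assay, an aromatic ring alone does not keep the number low: an 8.3-fold higher number from compound 3 to compound 4 (0.92 log units; beyond the scatter) and a 9.2-fold higher number from compound 2 to compound 4 (0.96 log units; beyond the scatter) are both beyond the scatter, so the flat step a 1.1-fold higher number from compound 2 to compound 3 (0.05 log units; within the scatter) does not extend to 4-aminophenyl. With the phenyl ring held, the change of ethoxy to amino on an aromatic carbon is enough to lose most of the gain made on leaving propyl, and only a 2.1-fold lower number from compound 1 to compound 4 (0.33 log units; beyond the scatter) remains for 4-aminophenyl. No measurement shown offers an explanation for these steps.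

Open, going by these compounds, is whether the rise belongs to amino itself or to the absence of ethoxy, which a methoxy, hydroxyl or acetamido group on the same phenyl ring would help separate. Also open, on these data alone, is what the trifluoromethyl contributes to compound 3, which a methyl on the 1,3-thiazol-5-yl ring would test.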